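Terpenoid lactone side chains tested for K562 cytotoxicity

This account rests on a few compounds, and the source may have more. Where it says the series, first, only, none or still open, it means among the compounds named here.

Measured compounds:
Compound 1, `C=C1CC/C=C(\C)CC[C@@H]2[C@H](CC/C=C(\C)CO)C(=O)OC[C@@H]12`: 1.2 ug/mL
Compound 2, `C=C1CC/C=C(\C)CC[C@@H]2[C@H](C/C=C/C(C)(C)O)C(=O)OC[C@@H]12`: 2 ug/mL

Both compounds were tested in a functional assay on K562 cells (Homo sapiens) for cytotoxicity; a lower number here means that less compound is tolerated, a higher number that more compound is tolerated. Compound 1 gives 1.2 ug/mL and compound 2 gives 2 ug/mL, and the two numbers lie within the scatter of each other, so on the data shown compound 2 is not separated from compound 1. Among the measured compounds shown here, the only measured step is a 1.7-fold higher number from compound 1 to compound 2 (0.22 log units; within the scatter), which already swaps one hydroxylated side chain for another without a change beyond the scatter.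

Compound 3, `C=C1CC/C=C(\C)CC[C@@H]2[C@H](CC/C=C\CO)C(=O)OC[C@@H]12`, has not yet been measured in this assay. It differs from compound 2 in one place: 4-hydroxybut-2-en-1-yl in place of 3-hydroxy-3-methylbut-1-en-1-yl on a saturated chain carbon bound to a saturated ring carbon. The chain again keeps one hydroxyl group and one double bond, while losing a carbon. For the measured compounds named here, the one step that bears on this, a 1.7-fold higher number from compound 1 to compound 2 (0.22 log units; within the scatter), suggests that reshaping the side chain in this part of the molecule, while keeping a hydroxyl, does little to the number in this assay. The expected step is therefore a 1.1-fold lower number from compound 2 to compound 3 (0.05 log units; within the scatter), no change beyond the scatter. Compound 3 is estimated at 1.8 ug/mL, with a range from 0.8 ug/mL to 4 ug/mL.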

Compound 3, concentration lethal to 50% of the cells: 1.8 ug/mL
Compound 3: the middle estimate sits on the measured number at the digits printed, and the stated range covers the measured number.
By their numbers in this assay, from the lowest: compounds 1, 3 and 2 (each within the scatter of the next).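

In this assay, putting 4-hydroxybut-2-en-1-yl in place of 3-hydroxy-3-methylbut-1-en-1-yl on a saturated chain carbon bound to a saturated ring carbon gives a 1.1-fold lower number from compound 2 to compound 3 (0.05 log units; within the scatter), so a second reshaping of the side chain also fails to separate the numbers. The comparison with the first side chain reads the same way: 3-hydroxyprop-1-en-1-yl in place of 2-(hydroxymethyl)prop-1-en-1-yl, on a saturated chain carbon, two bonds along the chain from a saturated ring carbon, gives a 1.5-fold higher number from compound 1 to compound 3 (0.18 log units; within the scatter), which places all three hydroxylated side chains within the scatter of one another. Nothing available here offers an explanation for this close agreement.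

Every side chain shown carries a hydroxyl and a double bond, so the compounds leave open what happens to the number when that hydroxyl is replaced by an amine or a carboxylic acid. They also leave open whether a fully saturated or much longer chain at this position, on the same shared core, would move the number beyond the scatter.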